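A few compounds are considered here, and "the series" means these few. Any claim that something is new, unique, unknown or untested is made for them only; others in the source may bear on it.

Measured compounds:
Compound 1, `CC[C@H](C)[C@H](N)CN(C(=O)[C@@H]1C[C@H]1c1ccc(F)cc1)c1ccc(-c2ccccc2)cc1`, in a functional assay for agonist activity at G protein-coupled receptor 88 (Homo sapiens), read by HTRF and cAMP accumulation; on this read-out lower numbers stand for an effect already at smaller amounts and higher numbers for an effect only at larger amounts of compound: 600 nM
Compound 2, `CC(C)C[C@H](N)CN(C(=O)[C@@H]1C[C@H]1c1ccccc1)c1ccc(-c2ccoc2)cc1`, in this assay: 2000 nM

Of the two compounds measured, compound 2 stands at the higher number. Going by the values given here, the only comparison available is with compound 1, whose number is lower, and that gap lies beyond the usual scatter. Compound 1 and compound 2 differ in more than one place, so no single change can be read from them.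

Compound 3, `COc1ccc(-c2ccc(N(C[C@@H](N)CC(C)C)C(=O)[C@@H]3C[C@H]3c3ccccc3)cc2)cc1`, has not yet been measured. It differs from compound 2 in one place: 4-methoxyphenyl in place of furan-3-yl on an aromatic carbon. Nothing measured here isolates this particular exchange. The one point of reference is compound 1, which carries a six-membered all-carbon ring at the same position and gives the lower number, but other parts of its structure differ as well, so that comparison carries limited weight. On this basis a modest move toward a lower number is expected for compound 3, of a size around the edge of the scatter rather than clearly beyond it. Compound 3 is estimated at 1100 nM, with a range from 350 nM to 3500 nM. The expected step is a 1.8-fold lower number from compound 2 to compound 3 (0.26 log units; within the scatter).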

Compound 3, half-maximal effective concentration: 330 nM
For compound 3 the middle estimate is 3.3-fold (0.52 log units) above the measured one; measured number outside the range, below it.
By their numbers in this assay, from the lowest: compounds 3 and 1 (each within the scatter of the next); then compound 2.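

In this assay, going by these compounds alone, the exchange of furan-3-yl for 4-methoxyphenyl gives a step beyond the scatter (a 6.1-fold lower number from compound 2 to compound 3 (0.78 log units; beyond the scatter)), and it is the first change at this position that can be read on its own. It shows that this place, on an aromatic carbon of a six-membered aromatic ring of carbon only and para to a large group, takes a larger group with a lower number as the result: 8 heavy atoms enter where 5 leave, while the hydrogen-bond donor and acceptor counts and the net charge stay the same. No evidence is at hand that would explain this step.

As far as these compounds go, what stays open is whether the step belongs to the six-membered aromatic ring or to the methoxy group on it, as the phenyl of compound 1 sits on a structure that differs elsewhere too, and an unsubstituted phenyl, a 4-aminophenyl or a 4-ethoxyphenyl on the core of compound 3 would separate the two. Also open, from the compounds shown here alone, is whether the same exchange gives a similar step with the side chain and the 4-fluorophenyl group of compound 1 in place.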